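The compounds below may be only part of what the source reports. "The series", "measured", "known", "first", "only" and "open" are said of these compounds alone.

Compound 1 `C=C1CC[C@@H]2[C@](C)(CCC[C@]2(C)C(=O)O)[C@H]1C/C=C(\C)C=O` is one of the two measured compounds; in a functional assay on SMMC-7721 cells (Homo sapiens) for cytotoxicity, read by MTT assay, with a stated time of 48 h (a lower number here means a stronger inhibitor, a higher number a weaker inhibitor), compound 1 gives > 40000 nM, which is a limit of the assay and not a number.
Compound 2 `C=C[C@@](C)(O)CC[C@H]1C(=C)CC[C@@H]2[C@]1(C)CCC[C@]2(C)C(=O)O` is the other; in this assay compound 2 gives > 40000 nM, again a limit of the assay.

So compound 2 stands at the upper edge of what this assay can report, at the limit of > 40000 nM in this assay, at which 2 of the 2 values shown sit, and nothing finer is known about it. The unmeasured compound is compound 3 `C=C[C@]1(C)O[C@H]1C[C@H]1C(=C)CC[C@@H]2[C@]1(C)CCC[C@]2(C)C(=O)O`. It differs from compound 2 by a group of 6 heavy atoms (5 carbon, 1 oxygen; one three-membered non-aromatic ring with 1 hetero atom) in place of a group of 6 heavy atoms (5 carbon, 1 oxygen; no ring), on a saturated chain carbon bound to a saturated ring carbon.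

Among the compounds with values here, only one measured step exists, a step that the two limits leave unreadable from compound 1 to compound 2, and its size cannot be read because both of its ends sit at the limit of > 40000 nM in this assay, at which 2 of the 2 values shown sit. Within the data shown here, that step also concerns a different exchange of groups from the one between compound 2 and compound 3, so it gives no guide to direction or size for the change at hand. Nothing in the data therefore points to a step beyond the scatter.

Compound 3 is expected to sit near 40000 nM, with a range from 15000 nM to 100000 nM, most probably again reported only as a limit. The step this estimate implies, a number no higher from compound 2 to compound 3 (the limit leaves the size open), is expected to lie within the scatter.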

Compound 3, half-maximal inhibitory concentration: > 40000 nM
Compound 3 ended at the assay's limit (the forecaster's own chance of this, stated with the estimate: 70%); the middle value lies on the limit itself.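

No step can be read among compound 1, compound 2 and compound 3, since each gives only a limit of the assay and not a number: the limit of > 40000 nM in this assay, at which 3 of the 3 values shown sit.

The compounds shown leave open how strong any of the three really is in this assay, and whether exchanging these side chains on the shared core changes that strength at all.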